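Trading 6-bromopyridin-2-yl for cyclohexyl

The source may hold more compounds than are shown below. What is called first, only, known or untested is meant among the compounds shown, and "the series" means these compounds.

- compound 1 `Nc1ncnc2c(C(=O)Nc3cccc4c3c(Br)nn4Cc3ccccc3)csc12` gives 1010 nM
- compound 2 `Nc1ncnc2c(C(=O)Nc3cccc4c3c(Br)nn4Cc3cccc(Br)n3)csc12` gives 243 nM

Both numbers come from a functional assay on NFS-60 cells (Mus musculus) for inhibition, with a stated time of 72 h (a lower number here means a stronger inhibitor of growth, a higher number a weaker inhibitor of growth), and compound 2 has the lower of the two, which makes it the stronger inhibitor of growth so far. The next compound, compound 3 `Nc1ncnc2c(C(=O)Nc3cccc4c3c(Br)nn4CC3CCCCC3)csc12`, differs from it in one place: cyclohexyl in place of 6-bromopyridin-2-yl on a saturated chain carbon bound to an aromatic nitrogen. Among the compounds with values here, only one measured step bears on this: a 4.2-fold lower number from compound 1 to compound 2 (0.62 log units; beyond the scatter), seen when 6-bromopyridin-2-yl took the place of phenyl. Compound 3 gives up that group for a ring of carbon only, as in compound 1, so much of that gain is expected to vanish. Within the data shown here, no cyclohexyl compound has been measured, so this remains uncertain. Expected here is a 3.1-fold higher number from compound 2 to compound 3 (0.49 log units; beyond the scatter) in this assay, meaning weaker inhibition. For compound 3 the estimate is 750 nM, with an expected range from 300 nM to 1900 nM overall.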

Compound 3, concentration for 50% growth inhibition: 254 nM
For compound 3 the middle estimate is 3.0-fold (0.47 log units) above the measured one; the measured number lies below the stated range.
By their numbers in this assay, from the lowest: compounds 2 and 3 (each within the scatter of the next); then compound 1.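

In this assay the swap to cyclohexyl gives a 1.0-fold higher number from compound 2 to compound 3 (0.02 log units; within the scatter) and so costs nothing measurable: on a saturated chain carbon bound to an aromatic nitrogen, a non-aromatic ring of carbon only serves as well as 6-bromopyridin-2-yl, so neither the ring nitrogen nor the bromine is required at this place. Within the data shown here, the other new comparison, a 4.0-fold lower number from compound 1 to compound 3 (0.60 log units; beyond the scatter) for cyclohexyl in place of phenyl, shows that the gain over compound 1 can be had without either of those atoms, leaving phenyl as the one group of the three that gives a weaker inhibitor of growth. Nothing available here explains why phenyl stands apart from the other two rings.

Going by these compounds, whether a ring is needed at all remains open, as a plain methyl could show. A piperidine ring, with its amine, or a longer chain carrying the cyclohexyl could also test how much change this place accepts.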